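The compounds below may be only part of what the source reports. "The series", "measured", "known", "first", "only" and "open" are said of these compounds alone.

Measured in a functional assay on DU-145 cells (Homo sapiens) for inhibition, read by trypan blue exclusion, with a stated time of 96 h; on this read-out lower numbers stand for stronger inhibition of growth and higher numbers for weaker inhibition of growth:
Compound 1 `CSc1ccc(/C=C(\C(=O)c2ccc(Br)cc2)S(=O)(=O)Cc2ccc(F)cc2)cc1`: 50000 nM
Compound 2 `CSc1ccc(/C=C(\C(=O)c2ccc(Br)cc2)S(=O)(=O)Cc2ccc(C)cc2)cc1`: 10000 nM

Of these two, compound 1 stands highest. Within the data shown here, the only measured step is a 5.0-fold lower number from compound 1 to compound 2 (0.70 log units; beyond the scatter), with methyl in place of fluoro on an aromatic carbon. Compound 3 `COc1ccccc1/C=C(\C(=O)c1ccc(Br)cc1)S(=O)(=O)Cc1ccc(F)cc1` keeps the fluoro of compound 1 and changes elsewhere: 2-methoxyphenyl in place of 4-(methylsulfanyl)phenyl on a double-bonded chain carbon bound to a double-bonded chain carbon. Among the measured compounds shown here, no step at this place has been measured, so the one known step serves only as a rough guide to size. A modest move towards a lower number is expected, although the data do not fix its direction. The expected step is a 2.5-fold lower number from compound 1 to compound 3 (0.40 log units; beyond the scatter). For compound 3 the estimate is 20000 nM, with an expected range from 4000 nM to 80000 nM.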

Compound 3, concentration for 50% growth inhibition: 25000 nM
Compound 3: middle estimate off by 1.3-fold (0.10 log units), on the low side; the range from low to high includes it.
By their numbers in this assay, from the lowest: compound 2; then compounds 3 and 1 (each within the scatter of the next).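

In this assay the change from 4-(methylsulfanyl)phenyl to 2-methoxyphenyl on a double-bonded chain carbon bound to a double-bonded chain carbon shows a 2.0-fold lower number from compound 1 to compound 3 (0.30 log units; within the scatter) and so does not separate these two groups. Among these compounds, this is the first reading at this position, which the earlier pair left untouched, and here an aromatic ring carrying a methoxy group stands in for one carrying methylsulfanyl without a change beyond the scatter. No evidence is available that bears on this result. Still open, from the compounds shown here alone, is whether an amine or a carboxylic acid on this ring would move the number beyond the scatter. Also open, going by these compounds, is whether methyl in place of fluoro would give a similar step with 2-methoxyphenyl present.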